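A few compounds are considered here, and "the series" means these few. Any claim that something is new, unique, unknown or untested is made for them only; others in the source may bear on it.

Compound 1 `Cc1[nH]n(-c2nc3cc(Cl)ccc3[nH]2)c(=O)c1Cc1ccccc1` stands highest of the two results in a functional assay on DU-145 cells (Homo sapiens) for antiproliferative activity, read by WST assay, with a stated time of 48 h, tested at 1 uM (on this read-out lower numbers stand for a weaker effect and higher numbers for a stronger effect at the one concentration tested), giving 86%. For the measured compounds named here, compound 2 `Cc1nn(-c2nc3ccccc3[nH]2)c(O)c1Cc1ccccc1` gives 42% in this assay, a gap beyond the usual scatter; no single-place step links these two structures, so only their values are set side by side. Compound 3 `Cc1[nH]n(-c2nc3cc(C(F)(F)F)ccc3[nH]2)c(=O)c1Cc1ccccc1` has not yet been measured in this assay. It differs from compound 1 in one place: trifluoromethyl in place of chloro on an aromatic carbon. Going by the values given here, no measured step of this kind is at hand. For compound 3 the expected step is a number 6 percentage points lower from compound 1 to compound 3 (within the scatter), at most the scatter in either direction. Compound 3 is estimated at 80%, within 60% to 95%.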

Compound 3, a percentage reported as inhibition, at one concentration (the size of the read-out at that concentration, not a potency): 78%
Compound 3: middle estimate off by 2 percentage points, on the high side; measured number inside the range.
By their numbers in this assay, from the lowest: compound 2; then compounds 3 and 1 (each within the scatter of the next).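

In this assay, trifluoromethyl in place of chloro on an aromatic carbon gives a number 8 percentage points lower from compound 1 to compound 3 (within the scatter), so this position of the core of compound 1 accepts a group of four heavy atoms where one stood, without a change beyond the scatter. For the compounds shown here, this is the first single-place comparison, and it covers only these two groups. Nothing measured here accounts for the two compounds reading alike.

Going by these compounds, whether an amine or a carboxylic acid at this position would keep the effect remains open. So does what any single change elsewhere on the core of compound 1 would do.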